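The source may report more compounds than this note shows. Statements on the series, on what has been measured and on what is new or still open speak of the compounds shown alone.

Measured compounds:
compound 1 `O=C(/C=C/c1cn(S(=O)(=O)c2cccc([N+](=O)[O-])c2)c2ccccc12)c1ccncc1` gives 42600 nM
compound 2 `O=C(/C=C/c1cn(S(=O)(=O)c2cccc3ccccc23)c2ccccc12)c1ccncc1` gives 62900 nM

Going by the values given here, in a functional assay on HepG2 cells (Homo sapiens) for antiproliferative activity, read by MTT assay, with a stated time of 48 h (on this read-out higher numbers stand for weaker inhibition and lower numbers for stronger inhibition), compound 2 sits at one end of the two numbers, but its only neighbour, compound 1, differs by a 1.5-fold higher number from compound 1 to compound 2 (0.17 log units; within the scatter), which lies within the scatter, so the two are not distinguishable. Compound 3 `O=C(/C=C/c1cn(S(=O)(=O)c2ccc(Cl)cc2Cl)c2ccccc12)c1ccncc1` differs from compound 2 by 2,4-dichlorophenyl in place of naphthalen-1-yl on a sulfonyl sulfur. Among the compounds with values here, the sole step bearing on this change, the earlier swap of groups on the same sulfonyl sulfur, moved nothing beyond the scatter, so compound 3 is expected to show a 1.3-fold lower number from compound 2 to compound 3 (0.10 log units; within the scatter). The estimate for compound 3 is 50000 nM, within 20000 nM to 125000 nM.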

Compound 3, half-maximal inhibitory concentration: 14800 nM
The estimate for compound 3 lay 3.4-fold (0.53 log units) above the measured number; the measured number lies below the stated range.
By their numbers in this assay, from the lowest: compound 3; then compounds 1 and 2 (each within the scatter of the next).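

In this assay, the group on the sulfonyl sulfur turns out to matter, which the earlier swap, within the scatter, did not show. Putting 2,4-dichlorophenyl there gives a 4.3-fold lower number from compound 2 to compound 3 (0.63 log units; beyond the scatter) in place of naphthalen-1-yl, and a 2.9-fold lower number from compound 1 to compound 3 (0.46 log units; beyond the scatter) in place of 3-nitrophenyl, making compound 3 the most potent of the three. No measurement available here explains this gain. Still open, from the compounds shown here alone, is whether the gain needs both chlorine atoms, and how a phenyl carrying a single chlorine, a methoxy group or an amine would compare.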